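The source may hold more compounds than are shown below. What is called first, only, known or untested is meant among the compounds shown, and "the series" means these compounds.

Of the compounds shown here, two have so far been tested in an assay on membranes from brain for displacement of a labelled ligand from Sigma non-opioid intracellular receptor 1 (Cavia porcellus), read by radioligand binding; a lower number here means a stronger inhibitor, a higher number a weaker inhibitor. Compound 1 `COc1ccc(CNCCCCc2cn(-c3ccc(F)cc3)c3ccccc23)cc1` gives 129 nM. Compound 2 `CCN(CCCCc1cn(-c2ccc(F)cc2)c2ccccc12)[C@H]1CCc2c1ccc(OC)c2OC` gives 50.8 nM, the lowest of the two numbers, and compound 1 is its nearest neighbour with a gap beyond the usual scatter. Compound 3 `CCN(CCCCc1cn(-c2ccc(F)cc2)c2ccccc12)[C@@H]1CCc2c1ccc(OC)c2OC` is the next step from compound 2: the two compounds have the same atoms and bonds and differ only in configuration as drawn: 1 of 1 stereo elements differ; a stereocentre at a saturated ring carbon is drawn S in compound 2 and R in compound 3. Among the compounds with values here, no tested pair differs only in this way, so the size of the step in this assay is open; a moderate rise is expected. Compound 3 is expected to give 110 nM, with a range from 25 nM to 500 nM. The expected step is a 2.2-fold higher number from compound 2 to compound 3 (0.34 log units; beyond the scatter).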

Compound 3, inhibition constant: 126 nM
For compound 3 the middle estimate is 1.1-fold (0.06 log units) below the measured one; the measured number falls inside the stated range.
By their numbers in this assay, from the lowest: compound 2; then compounds 3 and 1 (each within the scatter of the next).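

The spatial arrangement at one stereocentre, at a saturated ring carbon, is enough to shift binding in this assay: changing it from S to R gives a 2.5-fold higher number from compound 2 to compound 3 (0.39 log units; beyond the scatter). Within the data shown here, this modest loss is the first effect that can be traced to a single change. The S form binds more strongly, and the cause of the shift can be placed at this stereocentre because nothing else separates the pair: the fact that compounds 2 and 3 differ only in the configuration as drawn

A single pair cannot show whether S stays favoured across the series. It also leaves open whether this preference would survive swapping a methoxy group for a carboxylic acid, or the amine's substituent for a longer chain.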